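This account rests on a few compounds, and the source may have more. Where it says the series, first, only, none or still open, it means among the compounds named here.

Measured compounds:
compound 1 `C[C@H](Nc1nc(Cl)nc(NC(C)(C)C)n1)c1ccccc1` — 3310 nM
compound 2 `CCNc1nc(Cl)nc(N[C@H](C)c2ccccc2)n1` — 14100 nM
compound 3 `CC(C)N(c1nc(Cl)nc(N[C@H](C)c2ccccc2)n1)C(C)C` — 1620 nM

In an ADME assay on the whole organism for inhibition, with Oryza sativa as the target, with a stated time of 4 days (a lower number here means a stronger inhibitor, a higher number a weaker inhibitor), compound 1 gives 3310 nM, which places it second highest of the three numbers: compound 3 lies lower at 1620 nM, beyond the scatter, while compound 2 lies higher at 14100 nM, also beyond the scatter. Compound 4 `CCCNc1nc(Cl)nc(N[C@@H](C)c2ccccc2)n1` is the next compound to be tested. It differs from compound 1 in one place: propyl in place of tert-butyl on a nitrogen on an aromatic ring.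

Going by the values given here, the only measured step at this nitrogen runs from compound 2 to compound 3, an 8.7-fold lower number from compound 2 to compound 3 (0.94 log units; beyond the scatter), where a larger branched group in place of ethylamino gave a clearly lower number. Compound 1 fits the same picture, since its tert-butylamino group gives a lower number than the ethylamino group of compound 2. Propyl stands between ethyl and tert-butyl in size, so the number for compound 4 is expected to rise relative to compound 1 by less than the gap between compound 2 and compound 1. The expected step is a 2.1-fold higher number from compound 1 to compound 4 (0.33 log units; beyond the scatter). The estimate for compound 4 is therefore 7000 nM, with a range from 3000 nM to 16000 nM.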

Compound 4, half-maximal inhibitory concentration: 32400 nM
The estimate for compound 4 lay 4.6-fold (0.67 log units) below the measured number; the measured number lies above the stated range.
By their numbers in this assay, from the lowest: compound 3; then compound 1; then compound 2; then compound 4.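

In this assay, the change to propyl in place of tert-butyl on a nitrogen on an aromatic ring gives a 9.8-fold higher number from compound 1 to compound 4 (0.99 log units; beyond the scatter), so losing a single carbon and the branching at this nitrogen is enough to raise the number well beyond the scatter, and carbon count alone does not track the result. Going by these compounds alone, this is also the first step at this nitrogen on the stereocentre configuration of compound 1, whereas an 8.7-fold lower number from compound 2 to compound 3 (0.94 log units; beyond the scatter) was read on the opposite configuration, and in both steps the compound with the branched group has the lower number, with no compound here going against that. No measurement offered here explains the size of the rise from the tert-butyl group to the propyl group.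

The compounds shown leave open whether branching itself or the particular group matters, which isopropylamino, cyclopropylamino or a longer chain such as butylamino on the core of compound 1 would help to separate. They also leave open how far the order of groups at this nitrogen depends on the configuration of the stereocentre, since no group appears here on both configurations.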